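Phenyl gives way to propyl: what to expect

A few compounds are considered here, and "the series" means these few. Any claim that something is new, unique, unknown or untested is made for them only; others in the source may bear on it.

Measured in a functional assay on HL-60 cells (Homo sapiens) for antiproliferative activity, read by MTT assay; a higher number here means a weaker inhibitor, a lower number a stronger inhibitor:
- compound 1 `C=CC[C@@H]1O[C@H](COCc2ccccc2)[C@@H](OCc2ccccc2)[C@H](OCc2ccccc2)[C@H]1O` gives 15100 nM
- compound 2 `O[C@@H]1[C@@H](OCc2ccccc2)[C@H](OCc2ccccc2)[C@@H](COCc2ccccc2)O[C@H]1Cc1ccccc1` gives 8700 nM
- compound 3 `O[C@@H]1[C@@H](O)[C@H](Cc2ccccc2)O[C@H](COCc2ccccc2)[C@H]1OCc1ccccc1` gives 26600 nM

Compound 2 cannot be told apart from compound 1 on these numbers, and it stands apart only from compound 3. Putting phenyl in place of vinyl on a saturated chain carbon bound to a saturated ring carbon gives a 1.7-fold lower number from compound 1 to compound 2 (0.24 log units; within the scatter). Putting hydrogen in place of benzyl on an oxygen gives a 3.1-fold higher number from compound 2 to compound 3 (0.49 log units; beyond the scatter).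

The next compound, compound 4 `CCCC[C@@H]1O[C@H](COCc2ccccc2)[C@@H](OCc2ccccc2)[C@H](OCc2ccccc2)[C@H]1O`, has propyl in place of phenyl on a saturated chain carbon bound to a saturated ring carbon. The same difference, cut one bond further out, reads benzyl to butyl.

The first step is the better guide, since it changes the same place. Compound 1 also has no phenyl there, and the swap in that step gave only a 1.7-fold lower number from compound 1 to compound 2 (0.24 log units; within the scatter). The second step changes a different place and says little here. A small rise in this assay, probably no larger than the scatter, therefore seems likely. The expected change is a 1.5-fold higher number from compound 2 to compound 4 (0.17 log units; within the scatter). For compound 4 the estimated value is 13000 nM, with an expected range from 6000 nM to 28000 nM.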

Compound 4, half-maximal inhibitory concentration: "not active" (no number reported)
The entry for compound 4 holds no number, and the estimate cannot be compared.
By their numbers in this assay, from the lowest: compounds 2, 1 and 3 (each within the scatter of the next, the first and the last beyond it).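

In this assay, going by these compounds alone, compound 4 is recorded only as "not active", without a number, so no step from compound 2 or compound 1 to compound 4 can be read. Nothing available here offers an explanation for this result. The compounds shown leave open how large the effect of butyl in place of benzyl at this position really is.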